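This account rests on a few compounds, and the source may have more. Where it says the series, first, only, none or still open, it means among the compounds named here.

Within the data shown here, in an ADME assay on a cell-free system (plasma, Rattus norvegicus) for metabolic stability, read by LC-MS, with a stated time of 1 h, at 37 degrees C, tested at 100 uM (on this read-out lower numbers stand for a less stable compound and higher numbers for a more stable compound), compound 1 `Cc1ccc(C(=O)O)cc1-c1cccc(COc2ccc3c(c2)CN(C2CCCC2)C3=O)c1` gives 100%, the highest of the two numbers so far; compound 2 `O=C(O)c1cc(-c2cccc(-c3ccc4c(c3)CN(C3CCCC3)C4=O)c2)ccc1Cl` gives 81% in this assay, a gap that lies beyond the usual scatter, so compound 1 is the more stable of the pair. Compound 3 `O=C(O)c1ccc(Cl)c(-c2cccc(COc3ccc4c(c3)CN(C3CCCC3)C4=O)c2)c1` is the next point in this assay. Compound 3 differs from compound 1 by chloro in place of methyl on an aromatic carbon. With no measured step of this kind in hand, the expected change from compound 1 to compound 3 in this assay is small, at most a slight loss, as a number 6 percentage points lower from compound 1 to compound 3 (within the scatter). For compound 3 the estimated value in this assay is 94%, within 80% to 100%.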

Compound 3, percent of the compound remaining: 100%
Beside the measured number, compound 3's estimate is 6 percentage points below it; the range from low to high includes it.
By their numbers in this assay, from the lowest: compound 2; then compounds 1 and 3 (each within the scatter of the next).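

This first measured step at this position reads no change at the digits printed from compound 1 to compound 3 (within the scatter) in this assay, so on this aromatic carbon chloro in place of methyl leaves the read-out unmoved. With compound 3 at 100%, the pair sits at the top of the scale, where any gain would be hidden. No evidence here accounts for the two groups reading alike.

Open, going by these compounds, is whether a methoxy group or an amine on this carbon would read the same. Also open, on these data alone, is how an ethyl ester in place of the carboxy group would fare in this assay.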